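Fluorobenzyl triazole chalcones: growth inhibition working notes

A few compounds are considered here, and "the series" means these few. Any claim that something is new, unique, unknown or untested is made for them only; others in the source may bear on it.

Measured in a functional assay on MCF7 cells (Homo sapiens) for inhibition, read by MTT assay, with a stated time of 48 h, tested at 10 uM (a higher number here means more inhibition of growth at the concentration tested, a lower number less inhibition of growth), so far:
compound 1 `O=C(/C=C/c1ccc(OCc2cn(Cc3cccc(F)c3)nn2)cc1)c1ccc(Br)cc1` gives 42%
compound 2 `COc1ccc(C(=O)/C=C/c2ccc(OCc3cn(Cc4cccc(Br)c4)nn3)cc2)cc1` gives 45%
compound 3 `COc1ccc(C(=O)/C=C/c2ccc(OCc3cn(Cc4ccccc4F)nn3)cc2)cc1` gives 32%

Compound 3 holds the lowest of the three numbers in this assay. Compound 1 stands within the scatter of it, compound 2 beyond it. Going by the values given here, the one single-point step measured so far is a number 13 percentage points lower from compound 2 to compound 3 (beyond the scatter), a modest fall. Compound 4 `COc1ccc(C(=O)/C=C/c2ccc(OCc3cn(Cc4cccc(F)c4)nn3)cc2)cc1` differs from compound 3 by 3-fluorophenyl in place of 2-fluorophenyl on a saturated chain carbon bound to an aromatic nitrogen. Among the compounds with values here, no measured step covers this exact swap, and the pair of compound 1 and compound 2 differs in two places, so it gives only indirect guidance. Compound 1 carries the same 3-fluorophenyl group that enters here and sits within the scatter of compound 3, which argues against any large move in this assay. The step expected from this change is a number 8 percentage points higher from compound 3 to compound 4 (within the scatter), a rise that stays within the scatter. Compound 4 is therefore estimated at 40% in this assay, with a range from 28% to 52%.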

Compound 4, percent growth inhibition at one concentration: 41%
For compound 4 the middle estimate is 1 percentage points below the measured one, and the stated range covers the measured number.
By their numbers in this assay, from the lowest: compounds 3, 4, 1 and 2 (each within the scatter of the next, the first and the last beyond it).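

In this assay, 3-fluorophenyl in place of 2-fluorophenyl on a saturated chain carbon bound to an aromatic nitrogen gives a number 9 percentage points higher from compound 3 to compound 4 (within the scatter) and so shows no effect of fluorine placement that can be told from the scatter. Fluoro in place of bromo on an aromatic carbon gives a number 4 percentage points lower from compound 2 to compound 4 (within the scatter), so neither single change reaches the scatter alone, although the earlier step combining both, a number 13 percentage points lower from compound 2 to compound 3 (beyond the scatter), goes beyond it. Methoxy in place of bromo on an aromatic carbon gives a number 1 percentage points lower from compound 1 to compound 4 (within the scatter) and is equally unresolved, and nothing at hand bears on what lies behind these numbers.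

The compounds shown leave open whether an unsubstituted phenyl, an aminophenyl or a carboxyphenyl at this place would move the number beyond the scatter. They also leave open how a longer chain in place of the benzyl methylene would read in this assay.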